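The source may hold more compounds than are shown below. What is called first, only, known or untested is meant among the compounds shown, and "the series" means these compounds.

Compound 1 `CCn1c(C(=O)NC(C)(C)CO)ccc1C(CC)(CC)c1ccc(OCS(=O)(=O)c2ccccc2)c(C)c1`: in a functional assay on BXPC-3 cells (Homo sapiens) for antiproliferative activity, read by MTT assay, with a stated time of 24 h (a higher number here means a weaker inhibitor, a lower number a stronger inhibitor), compound 1 gives 18300 nM.
Compound 2 `CCn1c(C(=O)NCC(=O)O)ccc1C(CC)(CC)c1ccc(OCS(=O)(=O)c2ccccc2)c(C)c1`: in this assay compound 2 gives > 50000 nM, which is a limit of the assay and not a number.

Compound 1 therefore stands as the only compound with an actual number shown; the other value shown is a limit. The step of an at least 2.7-fold higher number from compound 1 to compound 2 (0.43 log units; beyond the scatter) shows that putting carboxymethyl in place of 1-(hydroxymethyl)-1-methylethyl on the amide-type nitrogen weakens inhibition. Compound 2 sits at the limit of > 50000 nM in this assay, at which 1 of the 2 values shown sits.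

Compound 3 `CCn1c(C(=O)N[C@H](C(=O)O)C(C)C)ccc1C(CC)(CC)c1ccc(OCS(=O)(=O)c2ccccc2)c(C)c1` differs from compound 1 as 1-carboxy-2-methylpropyl in place of 1-(hydroxymethyl)-1-methylethyl on an amide-type nitrogen. This change again exchanges the 1-(hydroxymethyl)-1-methylethyl group for a carboxy-bearing group on the amide-type nitrogen, and since the related step of an at least 2.7-fold higher number from compound 1 to compound 2 (0.43 log units; beyond the scatter) ran toward a weaker inhibitor, compound 3 is expected to move the same way. The expected step of a 2.5-fold higher number from compound 1 to compound 3 (0.39 log units; beyond the scatter) points to a higher number in this assay, and compound 3 is estimated at 45000 nM, within 15000 nM to 150000 nM, with a fair chance that only a limit is reported.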

Compound 3, half-maximal inhibitory concentration: 16200 nM
For compound 3 the middle estimate is 2.8-fold (0.44 log units) above the measured one; low and high end bracket the measured number.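

In this assay, a carboxy-bearing group on the amide-type nitrogen does not by itself weaken inhibition: 1-carboxy-2-methylpropyl in place of 1-(hydroxymethyl)-1-methylethyl gives a 1.1-fold lower number from compound 1 to compound 3 (0.05 log units; within the scatter), so this exchange leaves no readable change. What separates the two carboxy-bearing compounds is isopropyl in place of hydrogen on the saturated chain carbon bound to an amide-type nitrogen and a carbonyl carbon, with an at least 3.0-fold lower number from compound 2 to compound 3 (0.48 log units; beyond the scatter), so among the compounds shown the outcome follows that carbon's substituent and not the carboxy group alone. The figure for compound 2 is a limit of the assay and not a number: the limit of > 50000 nM in this assay, at which 1 of the 3 values shown sits.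

The compounds shown leave open whether a longer chain or a benzyl group on that carbon would match compound 3, and whether its defined stereocentre matters. They also leave open what a methyl ester or an amine would do in place of the carboxylic acid.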